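Carbamate chain variation on the selenocyanate series

A few compounds are considered here, and "the series" means these few. Any claim that something is new, unique, unknown or untested is made for them only; others in the source may bear on it.

Compound 3 `CCCCCCOC(=O)Nc1ccc([Se]C#N)cc1` gives 19700 nM in a functional assay on CCRF-CEM cells (Homo sapiens) for cytotoxicity, read by MTT assay, with a stated time of 72 h (a lower number here means a stronger inhibitor of growth, a higher number a weaker inhibitor of growth), the highest of the three numbers measured. Compound 1 `CC(C)COC(=O)Nc1ccc([Se]C#N)cc1` gives 9300 nM and compound 2 `C=CCOC(=O)Nc1ccc([Se]C#N)cc1` gives 9200 nM. The steps of a 2.1-fold higher number from compound 1 to compound 3 (0.33 log units; beyond the scatter) and a 2.1-fold higher number from compound 2 to compound 3 (0.33 log units; beyond the scatter) both show the pentyl chain carrying a modestly higher number than the shorter groups. Compound 4 `N#C[Se]c1ccc(NC(=O)OCc2ccccc2)cc1` differs from compound 3 by phenyl in place of pentyl on a saturated chain carbon bound to an oxygen next to a carbonyl group. Going by the values given here, no measured step places a phenyl at this position, so the change itself is untested; the two measured steps only show that leaving pentyl has gone with modestly lower numbers. The expected step for compound 4 in this assay is therefore a 2.0-fold lower number from compound 3 to compound 4 (0.29 log units; within the scatter). The estimate for compound 4 is 10000 nM, with a range from 4000 nM to 25000 nM.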

Compound 4, concentration for 50% growth inhibition: 23200 nM
Compound 4: middle estimate off by 2.3-fold (0.37 log units), on the low side; the measured number falls inside the stated range.
By their numbers in this assay, from the lowest: compounds 2 and 1 (each within the scatter of the next); then compounds 3 and 4 (each within the scatter of the next).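

In this assay phenyl and pentyl stand level at this position, with a 1.2-fold higher number from compound 3 to compound 4 (0.07 log units; within the scatter) within the scatter, so the ring does not bring the number towards those of the smaller groups. Phenyl instead stands apart from both, with a 2.5-fold higher number from compound 2 to compound 4 (0.40 log units; beyond the scatter) and a 2.5-fold higher number from compound 1 to compound 4 (0.40 log units; beyond the scatter) each beyond the scatter, and the lower numbers stay with compound 1 and compound 2. No evidence bearing on this result is available.

From the compounds shown here alone, whether a longer chain would stay level with compound 3 remains open. So does the effect of an amine or a carboxylic acid on the phenyl.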